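Cyano for Nitro on Two Sulfonamide Cores

The compounds below may be only part of what the source reports. "The series", "measured", "known", "first", "only" and "open" are said of these compounds alone.

Compound 1 `Cc1cc(CNS(=O)(=O)c2ccc([N+](=O)[O-])cc2)c(C)o1` in an ADME assay on MDCK cells (Canis lupus familiaris) for cytotoxicity, read by MTT assay, with a stated time of 24 h (a higher number here means that more compound is tolerated, a lower number that less compound is tolerated), gives > 152000 nM, which is a limit of the assay.
Compound 2 `Cc1cc(CNS(=O)(=O)c2ccc(C#N)cc2)c(C)o1` gives 105000 nM.
Compound 3 `O=[N+]([O-])c1ccc(S(=O)(=O)NCc2csc3ccccc23)cc1` gives > 191000 nM, again a limit of the assay.

Compounds 1 and 2 share a core and differ in one place: cyano in place of nitro on an aromatic carbon. The step is an at least 1.4-fold lower number from compound 1 to compound 2 (0.16 log units; that floor lies within the scatter), so the data for this pair give only a floor for how much lower compound 2 sits, and that floor is within the scatter. Compound 3 has a different core; the difference between the two cores is not broken down here. Compound 4 `N#Cc1ccc(S(=O)(=O)NCc2csc3ccccc23)cc1` has not yet been measured. It differs from compound 3 by cyano in place of nitro on an aromatic carbon, and since the place reads the same for both pairs, this is the same change as from compound 1 to compound 2.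

The expectation for compound 4 rests on that one measured step, an at least 1.4-fold lower number from compound 1 to compound 2 (0.16 log units; that floor lies within the scatter), and on the fact that compound 3 sits at the limit of > 191000 nM in this assay, at which 1 of the 3 values shown sits. A step of an at least 1.4-fold lower number from compound 3 to compound 4 (0.16 log units; that floor lies within the scatter) is expected. Compound 4 is estimated at 130000 nM, with 60000 nM to 300000 nM as the likely span, and a real chance that the assay again reports only a limit.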

Compound 4, half-maximal cytotoxic concentration: 122000 nM
Estimate against measurement, compound 4: 1.1-fold (0.03 log units) above; low and high end bracket the measured number.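

On the core of compound 3, cyano in place of nitro gives an at least 1.5-fold lower number from compound 3 to compound 4 (0.19 log units; that floor lies within the scatter) in this assay. Set beside the same change on the core of compound 1, this step can be read only as a floor, so the comparison stays open: the same change on two cores in this assay, an at least 1.4-fold lower number (0.16 log units; that floor lies within the scatter) from compound 1 to compound 2 and an at least 1.5-fold lower number (0.19 log units; that floor lies within the scatter) from compound 3 to compound 4; the limit leaves it open whether they differ

Compound 3 gives only a limit of the assay, > 191000 nM, so the true size of the step on this core is unknown, and the result shows neither that the change carries over from one core to the other by the same amount nor that it differs: the limit of > 191000 nM in this assay, at which 1 of the 4 values shown sits.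

The compounds shown carry only nitro or cyano at this place and only two cores, so it remains open how an amine, a carboxylic acid or a chlorine atom there would read in this assay. Also open, as far as these compounds go, is how a longer chain joining the sulfonamide to either core would read in this assay.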